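This account rests on a few compounds, and the source may have more. Where it says the series, first, only, none or still open, it means among the compounds named here.

Compound 1 `COc1cccc(S(=O)(=O)c2cnc3cc(F)ccc3c2-c2cccc(Cl)c2)c1` sits second highest of the three numbers in an ADME assay on microsomes from liver (Homo sapiens) for metabolic stability, tested at 2.5 uM (on this read-out lower numbers stand for slow clearance and higher numbers for fast clearance), and in that assay compound 1 gives 2.97 mL/min. Compound 2 `COc1cccc(S(=O)(=O)c2cnc3cc(F)ccc3c2-c2cccc(F)c2)c1` gives 3.36 mL/min, while compound 3 `O=S(=O)(c1ccc(F)cc1)c1cnc2c(F)cccc2c1-c1cccc(F)c1` gives 1.56 mL/min. Going by the values given here, the only measured step, a 1.1-fold higher number from compound 1 to compound 2 (0.05 log units; within the scatter), concerns a halogen swap on the ring that hangs from the shared core, not the group on the sulfonyl sulfur. Compound 4 `Cc1ccc(S(=O)(=O)c2cnc3cc(F)ccc3c2-c2cccc(Cl)c2)cc1F` differs from compound 1 by 3-fluoro-4-methylphenyl in place of 3-methoxyphenyl on a sulfonyl sulfur. Among the compounds with values here, no measured step touches this part of the molecule, so there is no direct guide; the one step that exists stayed within the scatter. Compound 4 is therefore expected to stay close to compound 1, with a 1.0-fold higher number from compound 1 to compound 4 (0.00 log units; within the scatter) expected to fall within the scatter. The estimate for compound 4 is 3 mL/min, ranging from 1.8 mL/min to 5 mL/min.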

Compound 4, intrinsic clearance in a liver preparation (reported as CLH), per the amount of preparation that the assay uses: 2.13 mL/min
The estimate for compound 4 lay 1.4-fold (0.15 log units) above the measured number, within the range that was stated.
By their numbers in this assay, from the lowest: compounds 3, 4, 1 and 2 (each within the scatter of the next, the first and the last beyond it).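

In this assay, 3-fluoro-4-methylphenyl in place of 3-methoxyphenyl on a sulfonyl sulfur gives a 1.4-fold lower number from compound 1 to compound 4 (0.14 log units; within the scatter). Going by these compounds alone, this is the first measured step at this position, and the read-out does not separate these two groups, although the entering group has a fluorine and a methyl where the leaving group has a methoxy. Nothing available explains this result. Still open, going by these compounds, is whether something other than a substituted phenyl on the sulfonyl sulfur, such as an amine or a longer alkyl chain, would also stay within the scatter of compound 1.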